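This account rests on a few compounds, and the source may have more. Where it says the series, first, only, none or still open, it means among the compounds named here.

Measured compounds:
compound 1 `COc1ccc(/C=C/C2(C)C=CC(=O)O2)c(OC)c1OC`, 71500 nM
compound 2 `COc1c(O)ccc(/C=C/C2(C)C=CC(=O)O2)c1OC`, 24600 nM
compound 3 `CC1(/C=C/c2ccc(O)cc2)C=CC(=O)O1`, 55300 nM

All three were run in a functional assay on UACC-62 cells (Homo sapiens) for inhibition, read by sulforhodamine B assay, with a stated time of 48 h; a lower number here means a stronger inhibitor of growth, a higher number a weaker inhibitor of growth. Compound 2 carries the lowest number of the three. Compound 3 and compound 1 lie within the scatter of each other, so no order between them is claimed.

One change recurs in the set: methyl in place of hydrogen on an oxygen on an aromatic ring. Between compound 2 and compound 1 it is measured, giving a 2.9-fold higher number from compound 2 to compound 1 (0.46 log units; beyond the scatter). The difference between the cores of compound 2 and compound 3 is not broken down here.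

Compound 4 `COc1ccc(/C=C/C2(C)C=CC(=O)O2)cc1` is not yet measured. It differs from compound 3 by methyl in place of hydrogen on an oxygen on an aromatic ring. For the measured compounds named here, the place lines for this change and for the one from compound 2 to compound 1 read the same word for word, so this is the same change made on a different core. Going by the values given here, only one measured instance exists, and on a core that is not broken down against that of compound 3, so the expectation rests on a single step.

In this assay, among the compounds with values here, compound 4 is expected to give 130000 nM, with a range from 55000 nM to 300000 nM, because the one measured instance of this change gave a 2.9-fold higher number from compound 2 to compound 1 (0.46 log units; beyond the scatter). The expected step is a 2.4-fold higher number from compound 3 to compound 4 (0.37 log units; beyond the scatter) for compound 4. Compound 3 already gives 55300 nM, a high number in this assay, so compound 4 is expected to sit higher still.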

Compound 4, concentration for total growth inhibition: 147000 nM
Beside the measured number, compound 4's estimate is 1.1-fold (0.05 log units) below it, within the range that was stated.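

In this assay, methyl in place of hydrogen on an oxygen on an aromatic ring, read here as hydroxy to methoxy, gives a 2.7-fold higher number from compound 3 to compound 4 (0.42 log units; beyond the scatter). Set beside the earlier instance, the step carries over between the two cores with no difference that can be told apart: the same change on two cores in this assay, a 2.9-fold higher number (0.46 log units; beyond the scatter) from compound 2 to compound 1 and a 2.7-fold higher number (0.42 log units; beyond the scatter) from compound 3 to compound 4, 1.1-fold (0.04 log units) apart, within the scatter of two such steps This shows that, for these two pairs and in this one read-out, capping the hydroxy goes with a weaker inhibitor of growth by a similar amount on both cores, but two pairs do not establish a rule for the series, and nothing here shows why the step has this size or whether it would hold on any other core or in any other cell line.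

The compounds shown leave open how the number responds when that oxygen carries a longer chain, such as ethyl, or when an amine or a carboxylic acid stands on the aromatic ring in place of the hydroxy. What each further methoxy group on the core of compound 2 contributes on its own also remains unresolved.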